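A few compounds are considered here, and "the series" means these few. Any claim that something is new, unique, unknown or untested is made for them only; others in the source may bear on it.

Compound 3 `C=C(Br)C(=O)Nc1cccc(-c2cn3nc(-c4ccc(Cl)cc4)sc3n2)c1` gives 1400 nM in a functional assay on L1210 cells (Mus musculus) for inhibition, read by cell counting, with a stated time of 2 days (on this read-out higher numbers stand for weaker inhibition and lower numbers for stronger inhibition), and stands second highest of the three numbers: its nearest neighbour is compound 2 `C=C(Br)C(=O)Nc1cccc(-c2cn3nc(Cc4cccc(OC)c4)sc3n2)c1` at 2000 nM and its furthest is compound 1 `C=C(Br)C(=O)Nc1cccc(-c2cn3nc(-c4ccc(C)cc4)sc3n2)c1` at 920 nM, both within the scatter. Compound 4 `C=C(Br)C(=O)Nc1cccc(-c2cn3nc(-c4ccccc4)sc3n2)c1` differs from compound 3 by hydrogen in place of chloro on an aromatic carbon. Going by the values given here, only one measured step touches that position, a 1.5-fold higher number from compound 1 to compound 3 (0.18 log units; within the scatter), and it lies within the scatter; the steps of a 2.2-fold higher number from compound 1 to compound 2 (0.34 log units; beyond the scatter) and a 1.4-fold lower number from compound 2 to compound 3 (0.15 log units; within the scatter) alter another part of the molecule. Because exchanging one substituent for another there gave a 1.5-fold higher number from compound 1 to compound 3 (0.18 log units; within the scatter), removing the substituent is expected to give a step of no change at the digits printed from compound 3 to compound 4 (within the scatter), within the scatter. Compound 4 is therefore estimated at 1400 nM, with a likely range from 700 nM to 2800 nM.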

Compound 4, half-maximal inhibitory concentration: 600 nM
Beside the measured number, compound 4's estimate is 2.3-fold (0.37 log units) above it, outside the stated range (below it).
By their numbers in this assay, from the lowest: compounds 4, 1, 3 and 2 (each within the scatter of the next, the first and the last beyond it).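

In this assay, the position para to a large group proves sensitive to chloro: a 2.3-fold lower number from compound 3 to compound 4 (0.37 log units; beyond the scatter), a step beyond the scatter, while hydrogen and methyl cannot be told apart, with a 1.5-fold lower number from compound 1 to compound 4 (0.19 log units; within the scatter). The exchange of the 3-methoxybenzyl group also now reads beyond the scatter with phenyl, at a 3.3-fold lower number from compound 2 to compound 4 (0.52 log units; beyond the scatter), whereas with 4-chlorophenyl it stayed within it. As far as these compounds go, whether a fluoro, an amine or a carboxylic acid at that position would follow chloro or methyl remains open. Nothing given here explains these steps.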